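Swapping the Acyl Group on a Shared Core

The source may report more compounds than this note shows. Statements on the series, on what has been measured and on what is new or still open speak of the compounds shown alone.

Of the compounds shown here, three have been tested in a functional assay on HeLa cells (Homo sapiens) for cytotoxicity, read by MTT assay, with a stated time of 72 h; a lower number here means a stronger inhibitor, a higher number a weaker inhibitor. Compound 1 `CC(=O)N(/N=N/c1ccc([N+](=O)[O-])cc1)c1ccc([N+](=O)[O-])cc1` gives 63000 nM. Compound 2 `O=C(c1ccccc1F)N(/N=N/c1ccc([N+](=O)[O-])cc1Br)c1ccc([N+](=O)[O-])cc1Br` gives 1200 nM. Compound 3 `O=C(c1cccc(C(F)(F)F)c1)N(/N=N/c1ccc([N+](=O)[O-])cc1C(F)(F)F)c1ccc([N+](=O)[O-])cc1C(F)(F)F` gives 750 nM, the lowest of the three numbers; its gap to compound 2 lies within the scatter, while its gap to compound 1 lies beyond it.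

Compound 4 `CCOC(=O)CC(=O)N(/N=N/c1ccc([N+](=O)[O-])cc1C(F)(F)F)c1ccc([N+](=O)[O-])cc1C(F)(F)F` has not been measured. It differs from compound 3 by (ethoxycarbonyl)methyl in place of 3-(trifluoromethyl)phenyl on a carbonyl carbon. Going by the values given here, no measured pair shows this change, so the expectation rests on the spread of the three values: compound 1, the only one without an aromatic ring on the carbonyl carbon, gives 63000 nM, far weaker than compound 3. Compound 4 is therefore expected to be weaker than compound 3, by a step of a 4.0-fold higher number from compound 3 to compound 4 (0.60 log units; beyond the scatter) in this assay. The estimated value of compound 4 is 3000 nM, with a range from 800 nM to 12000 nM.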

Compound 4, half-maximal inhibitory concentration: 300 nM
For compound 4 the middle estimate is 10-fold (1.00 log units) above the measured one; the measured number lies below the stated range.
By their numbers in this assay, from the lowest: compound 4; then compounds 3 and 2 (each within the scatter of the next); then compound 1.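

In this assay, (ethoxycarbonyl)methyl in place of 3-(trifluoromethyl)phenyl on a carbonyl carbon gives a 2.5-fold lower number from compound 3 to compound 4 (0.40 log units; beyond the scatter), a modest gain. In this one pair, then, a low number does not depend on an aromatic ring at this position, and a ringless chain carrying an ester does better than the ring it replaces. Nothing available explains why the number falls.

Still open, on these data alone, is whether the ester itself matters, since a carboxylic acid, an amide or a longer chain at this position could separate the ester from the chain. Whether the step holds on other cores is also unknown.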